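Ethyl for Trifluoromethyl on a Chain Carbon

A few compounds are considered here, and "the series" means these few. Any claim that something is new, unique, unknown or untested is made for them only; others in the source may bear on it.

Measured so far:
Compound 1, `Cn1cncc1CN1CC(N(CC2CCN(C(=O)CNC(=O)OC(C)(C)C)CC2)S(=O)(=O)c2ccccn2)Cc2cc(C#N)ccc21`; in an ADME assay on Caco-2 cells (Homo sapiens) for permeability, in the apical to basolateral direction (on this read-out higher numbers stand for higher permeability and lower numbers for lower permeability), compound 1 gives 0.5 10^-6 cm/s.
Compound 2, `Cn1cncc1CN1CC(N(CC2CCN(C(=O)CC(F)(F)F)CC2)S(=O)(=O)c2ccccn2)Cc2cc(C#N)ccc21`; in this assay compound 2 gives 0.5 10^-6 cm/s.

Both compounds share the same core and differ only on a saturated chain carbon bound to a carbonyl carbon. Within the data shown here, the one measured step, no change at the digits printed from compound 1 to compound 2 (within the scatter), shows that swapping the (tert-butoxycarbonyl)amino group for trifluoromethyl left the read-out where it was. Compound 2 therefore stands level with compound 1, and nothing in these two numbers tells the two apart.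

Compound 3, `CCCC(=O)N1CCC(CN(C2Cc3cc(C#N)ccc3N(Cc3cncn3C)C2)S(=O)(=O)c2ccccn2)CC1`, has not yet been measured. Its change from compound 2 is ethyl in place of trifluoromethyl on a saturated chain carbon bound to a carbonyl carbon. Among the measured compounds shown here, the only step on record, from compound 1 to compound 2, touches the same place and was flat, so it is the one bearing on this change, though it removed a much larger group than is removed here.

For the measured compounds named here, with that flat step as the only guide, compound 3 is expected to stay close to compound 2 in this assay, with a 1.2-fold higher number from compound 2 to compound 3 (0.08 log units; within the scatter) as the expected shift. The estimate for compound 3 is 0.6 10^-6 cm/s, with a range from 0.2 10^-6 cm/s to 1.5 10^-6 cm/s.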

Compound 3, apparent permeability: 0.5 10^-6 cm/s
Compound 3: middle estimate off by 1.2-fold (0.08 log units), on the high side; the measured number falls inside the stated range.
By their numbers in this assay, from the lowest: compounds 1, 2 and 3 (each within the scatter of the next).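

In this assay, putting ethyl in place of trifluoromethyl gives no change at the digits printed from compound 2 to compound 3 (within the scatter) and putting ethyl in place of (tert-butoxycarbonyl)amino gives no change at the digits printed from compound 1 to compound 3 (within the scatter) as well. This position now carries three different groups that read alike, and the newest is a plain carbon group with no fluorine, so the three fluorine atoms of compound 2 are not needed to reach this reading, and neither is the carbamate part of compound 1. No measurement shown here offers an explanation for why these three compounds read alike.

Going by these compounds, what remains open is whether any group on this saturated chain carbon bound to a carbonyl carbon can move the number at all, for example an amine, a carboxylic acid or a longer chain such as hexyl, each of which would test the position with something unlike the three groups seen so far. Also open, on these data alone, is whether a change away from this place, on the shared core, would separate compounds that this position has so far left level in this assay.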